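The source may hold more compounds than are shown below. What is called first, only, known or untested is meant among the compounds shown, and "the series" means these compounds.

Of the compounds shown here, three that share one core have been tested in a functional assay on the whole organism for inhibition, with Mythimna separata as the target, with a stated time of 5 days; a higher number here means that more compound is needed for the effect, a lower number that less compound is needed. Compound 1 `CC(C)(C)n1ncc(OCc2nnc(-c3c(F)cccc3F)o2)c(Cl)c1=O` gives 45.4 ug/mL, and compound 2 `CC(C)(C)n1ncc(OCc2nnc(-c3ccccc3)o2)c(Cl)c1=O` gives 12.2 ug/mL, the difference between them being a 3.7-fold lower number from compound 1 to compound 2 (0.57 log units; beyond the scatter). For compound 3 `CC(C)(C)n1ncc(OCc2nnc(-c3ccco3)o2)c(Cl)c1=O` no number is known, only a limit of the assay, > 300 ug/mL. Compound 3 thus sits at the weak end of the measured set, at the limit of > 300 ug/mL in this assay, at which 1 of the 3 values shown sits. Both steps leading to it were sizeable: an at least 24-fold higher number from compound 2 to compound 3 (1.39 log units; beyond the scatter), and an at least 6.6-fold higher number from compound 1 to compound 3 (0.82 log units; beyond the scatter).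

Compound 4 `CC(C)(C)n1ncc(OCc2nnc(-c3ccc(Cl)cc3Cl)o2)c(Cl)c1=O` undoes that kind of change, with 2,4-dichlorophenyl in place of furan-2-yl on an aromatic carbon. The step that bears on this most directly is the large one from compound 2 to compound 3, which ran in the opposite direction; the step from compound 1 to compound 2 suggests that a halogenated phenyl may land somewhat above a bare phenyl. A clear decrease in this assay is therefore expected. Compound 4 is estimated at 30 ug/mL, within a range from 8 ug/mL to 120 ug/mL. That expectation corresponds to a step of an at least 10-fold lower number from compound 3 to compound 4 (1.00 log units; beyond the scatter).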

Compound 4, half-maximal effective concentration: 27.8 ug/mL
Compound 4: middle estimate off by 1.1-fold (0.03 log units), on the high side; the measured number falls inside the stated range.
By their numbers in this assay, from the lowest: compound 2; then compounds 4 and 1 (each within the scatter of the next). At a limit, above all of these: compound 3.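

The weak result for compound 3 does not extend to every substituted ring at this position: in this assay, 2,4-dichlorophenyl in place of furan-2-yl gives an at least 10-fold lower number from compound 3 to compound 4 (1.03 log units; beyond the scatter). Chlorine on the phenyl is tolerated, but it does not surpass the bare phenyl of compound 2, as shown by a 2.3-fold higher number from compound 2 to compound 4 (0.36 log units; beyond the scatter). The two halogenated phenyl groups cannot be told apart in this assay, with a 1.6-fold lower number from compound 1 to compound 4 (0.21 log units; within the scatter), so the data give no preference between 2,4-dichlorophenyl and 2,6-difluorophenyl.

Going by these compounds, the value for compound 3 is a limit and not a number, so the true size of its step remains unknown: the limit of > 300 ug/mL in this assay, at which 1 of the 4 values shown sits. It also remains open how a phenyl carrying a methoxy group, an amine or a carboxylic acid would compare at this position.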